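Adding a methoxy to the phenyl of compound 2

The compounds below may be only part of what the source reports. "The series", "measured", "known", "first", "only" and "open" are said of these compounds alone.

Measured in a functional assay on A549 cells (Homo sapiens) for antiproliferative activity, read by MTT assay, with a stated time of 72 h; a higher number here means a weaker inhibitor, a lower number a stronger inhibitor
- compound 1 (`COc1ncc(-c2ccc3c(c2)N(c2ccc(F)cc2)C(=O)CO3)cc1NS(=O)(=O)c1ccc(F)cc1`) gives 6500 nM
- compound 2 (`COc1ncc(-c2ccc3c(c2)N(c2ccccc2)C(=O)CO3)cc1NS(=O)(=O)c1ccc(F)cc1`) gives 3490 nM

Going by the values given here, compound 2 stands within the scatter of compound 1, the only other measured compound, so neither ranks ahead. Compound 3 (`COc1ccc(N2C(=O)COc3ccc(-c4cnc(OC)c(NS(=O)(=O)c5ccc(F)cc5)c4)cc32)cc1`) differs from compound 2 by methoxy in place of hydrogen on an aromatic carbon (methoxy in place of hydrogen on an aromatic carbon, phenyl to 4-methoxyphenyl). Among the compounds with values here, the one measured step bearing on this is a 1.9-fold lower number from compound 1 to compound 2 (0.27 log units; within the scatter) with hydrogen in place of fluoro on an aromatic carbon. Within the data shown here, no measured compound carries a methoxy, so no step beyond the scatter is expected in this assay and no direction is favoured. The estimate means a 1.3-fold higher number from compound 2 to compound 3 (0.11 log units; within the scatter) as the expected step. Compound 3 is expected at 4500 nM (estimated range 1800 nM to 11000 nM).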

Compound 3, half-maximal inhibitory concentration: 1350 nM
Compound 3: middle estimate off by 3.3-fold (0.52 log units), on the high side; measured number outside the range, below it.
By their numbers in this assay, from the lowest: compound 3; then compounds 2 and 1 (each within the scatter of the next).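

In this assay the aromatic carbon para to a large group proves responsive: methoxy in place of hydrogen gives a 2.6-fold lower number from compound 2 to compound 3 (0.41 log units; beyond the scatter) and methoxy in place of fluoro gives a 4.8-fold lower number from compound 1 to compound 3 (0.68 log units; beyond the scatter) as the steps beyond the scatter. Hydrogen and fluoro at this place stayed within the scatter of each other, so methoxy alone separates from them here. Nothing measured accounts for these steps.

Going by these compounds, whether the oxygen or the added carbon carries the step stays open. Ethoxy, hydroxy or dimethylamino at this place would test how far it extends.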